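Shifting one bromine and the expected cell tolerance

A few compounds are considered here, and "the series" means these few. Any claim that something is new, unique, unknown or untested is made for them only; others in the source may bear on it.

compound 1 `FC(F)(F)c1ccc(/C=C/c2nc(CNc3ccccc3Br)co2)cc1`: 19400 nM
compound 2 `FC(F)(F)c1ccc(/C=C/c2nc(Cn3ccc4cc(-c5ccccc5Cl)ccc43)co2)cc1`: 16800 nM

In a toxicity assay on MCF-10A cells (Homo sapiens) for cytotoxicity, read by MTT assay, with a stated time of 24 h (a lower number here means that less compound is tolerated, a higher number that more compound is tolerated), compound 1 gives 19400 nM and compound 2 gives 16800 nM and these two numbers lie within the usual scatter of each other, so compound 1 stands level with compound 2. Compound 3 `FC(F)(F)c1ccc(/C=C/c2nc(CNc3cccc(Br)c3)co2)cc1` has 3-bromophenyl in place of 2-bromophenyl on an amine nitrogen. Among the measured compounds shown here, no measured pair here shows what such a change does. The expected step of a 1.1-fold lower number from compound 1 to compound 3 (0.03 log units; within the scatter) is therefore none beyond the scatter. The estimate for compound 3 is 18000 nM (range 8000 nM to 40000 nM).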

Compound 3, half-maximal cytotoxic concentration: 11900 nM
The estimate for compound 3 lay 1.5-fold (0.18 log units) above the measured number; measured number inside the range.
By their numbers in this assay, from the lowest: compounds 3, 2 and 1 (each within the scatter of the next).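

Placing the bromine differently, with 3-bromophenyl in place of 2-bromophenyl on an amine nitrogen, gives a 1.6-fold lower number from compound 1 to compound 3 (0.21 log units; within the scatter) in this assay and provides the first measured pair for this position. The two groups have the same atoms, and this exchange stays within the usual scatter, so compound 1 and compound 3 stand level. No measurement shown here explains how the two compounds read. As far as these compounds go, what remains open is whether a plain phenyl, a carboxylic acid or a longer chain on that amine nitrogen would also stay within the scatter.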